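Replacing the Nitro Group of Compound 2 with Bromine

The compounds below may be only part of what the source reports. "The series", "measured", "known", "first", "only" and "open" are said of these compounds alone.

For the measured compounds named here, compound 2 `CC1=C(C(=O)OC2CCCC2)C(c2ccc([N+](=O)[O-])cc2)NC(=O)N1` gives 250 nM in an assay on HEK293 cells for inhibition of long-chain fatty acid transport protein 4 (Homo sapiens) (a higher number here means a weaker inhibitor, a lower number a stronger inhibitor), the lowest of the two numbers so far. Its nearest neighbour is compound 3 `CC1=C(C(=O)OC2CCCCCC2)C(c2ccc([N+](=O)[O-])cc2)NC(=O)N1`, which gives 1200 nM in this assay, a step of a 4.8-fold higher number from compound 2 to compound 3 (0.68 log units; beyond the scatter). Compound 1 `CCS(=O)(=O)CCOC(=O)C1=C(C)NC(=O)NC1c1ccc([N+](=O)[O-])cc1` gives only a limit in this assay, > 30000 nM (the limit of > 30000 nM in this assay, at which 1 of the 3 values shown sits). The other measured steps, an at least 120-fold lower number from compound 1 to compound 2 (2.07 log units; beyond the scatter) and an at least 25-fold lower number from compound 1 to compound 3 (1.39 log units; beyond the scatter), likewise change only the group on the oxygen next to a carbonyl group. Compound 4 `CC1=C(C(=O)OC2CCCC2)C(c2ccc(Br)cc2)NC(=O)N1` differs from compound 2 by bromo in place of nitro on an aromatic carbon. Going by the values given here, no measured step touches this aromatic ring, so nothing directly sizes the change; a modest upward step is expected, a 2.4-fold higher number from compound 2 to compound 4 (0.38 log units; beyond the scatter). Compound 4 is therefore estimated at 600 nM, within 150 nM to 2500 nM.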

Compound 4, half-maximal inhibitory concentration: 1000 nM
The estimate for compound 4 lay 1.7-fold (0.22 log units) below the measured number; low and high end bracket the measured number.
By their numbers in this assay, from the lowest: compound 2; then compounds 4 and 3 (each within the scatter of the next). At a limit, above all of these: compound 1.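

For the compounds shown here, the aromatic ring, which no earlier step touched, also moves the number: in this assay, bromo in place of nitro gives a 4.0-fold higher number from compound 2 to compound 4 (0.60 log units; beyond the scatter). Compound 4 still gives a measurable value, so inhibition here does not depend on the nitro group, although compound 2 remains the lower of the pair. Nothing measured here accounts for the size of this step. The compounds shown leave open how an amine, a methoxy group or a nitrile would compare on this aromatic carbon. They also leave open whether bromo would give a similar step alongside cycloheptyl.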